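The compounds below may be only part of what the source reports. "The series", "measured", "known", "first", "only" and "open" are said of these compounds alone.

Three compounds on one shared core have numbers in a functional assay for inhibition, with Homo sapiens as the target; a lower number here means a stronger inhibitor, a higher number a weaker inhibitor. Compound 1 (`Cc1cc2c(cc1C(=O)N=C(N)N)S(=O)(=O)C(C)(C)CC2C`) gives 1100 nM, compound 2 (`Cc1cc2c(cc1C(=O)N=C(N)N)S(=O)(=O)CC2C(C)C`) gives 77 nM and compound 3 (`Cc1cc2c(cc1C(=O)N=C(N)N)S(=O)(=O)C(C)(C)C2(C)O`) gives 102 nM. Compound 3 sits within the scatter of compound 2 and well beyond the scatter from compound 1, which has the higher number.

Within the data shown here, compound 4 (`Cc1cc2c(cc1C(=O)N=C(N)N)S(=O)(=O)C(C)(C)C2O`) has no measurement yet. Relative to compound 3 it carries hydrogen in place of methyl on a saturated ring carbon.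

Among the measured compounds shown here, no measured pair in this set isolates that change, so the expectation rests on thin evidence. For the measured compounds named here, the measured compounds differ from one another in more than one place, and the spread from compound 2 at 77 nM to compound 1 at 1100 nM shows only that numbers on this core can differ widely. Going by the values given here, the closest reference is compound 3 at 102 nM, the only measured compound with a hydroxyl-bearing ring carbon at this place. A small change towards a weaker inhibitor is expected, probably within the scatter, and the estimated step is a 1.7-fold higher number from compound 3 to compound 4 (0.22 log units; within the scatter). The range is kept wide given the lack of a matched pair. For compound 4 the expected value is 170 nM, with an estimated range of 55 nM to 550 nM.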

Compound 4, half-maximal inhibitory concentration: 258 nM
Estimate against measurement, compound 4: 1.5-fold (0.18 log units) below; the range from low to high includes it.
By their numbers in this assay, from the lowest: compounds 2 and 3 (each within the scatter of the next); then compound 4; then compound 1.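

In this assay, among these compounds, hydrogen in place of methyl on this saturated ring carbon gives a modest loss (a 2.5-fold higher number from compound 3 to compound 4 (0.40 log units; beyond the scatter)), and this is the first pair that differs in one place only. The step lies beyond the scatter, so this carbon of the five-membered ring, next to the ring atom that bears two methyl groups, is sensitive to a change as small as one methyl group, with the methyl-bearing compound 3 the stronger inhibitor of the pair. The compounds shown offer no measurement that would account for this step, so it stands as an observation on a single pair with no cause attached.

From the compounds shown here alone, a single pair gives only one direction at this carbon, so it remains open whether an ethyl group or a longer chain in place of the methyl would extend the trend or reverse it. Among the compounds shown here, also open is the part played by the hydroxyl on the same carbon, since no pair here isolates it, and an amine or a methoxy group in its place would address that question.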